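The source may hold more compounds than are shown below. What is called first, only, known or untested is meant among the compounds shown, and "the series" means these compounds.

In a functional assay on MGC-803 cells (Homo sapiens) for inhibition, read by sulforhodamine B assay (on this read-out lower numbers stand for stronger inhibition and higher numbers for weaker inhibition), three compounds sharing one core have been measured. Compound 1 (`O=C1C=C(Nc2ccc(Br)cc2)C(=O)c2c1nc1n2[C@H]2OC[C@@H](O)[C@H]2OC1`) gives 1010 nM, compound 2 (`COc1ccc(NC2=CC(=O)c3nc4n(c3C2=O)[C@H]2OC[C@@H](O)[C@H]2OC4)cc1`) gives 1680 nM, and compound 3 (`Cc1ccc(NC2=CC(=O)c3nc4n(c3C2=O)[C@H]2OC[C@@H](O)[C@H]2OC4)cc1C`) gives 860 nM. Compound 3 stands within the scatter of both of the others. The next compound is compound 4 (`O=C1C=C(Nc2cccc(Cl)c2)C(=O)c2c1nc1n2[C@H]2OC[C@@H](O)[C@H]2OC1`), which carries 3-chlorophenyl in place of 3,4-dimethylphenyl on an amine nitrogen. Going by the values given here, no measured step makes this exact exchange. Among the compounds with values here, the steps that bear on it exchange the group on that same nitrogen: a 1.2-fold lower number from compound 1 to compound 3 (0.07 log units; within the scatter), a 2.0-fold lower number from compound 2 to compound 3 (0.29 log units; within the scatter) and a 1.7-fold higher number from compound 1 to compound 2 (0.22 log units; within the scatter). All three stay within the scatter, so no step beyond the scatter is expected in this assay, and no direction is firmly indicated. The estimated step is a 1.2-fold higher number from compound 3 to compound 4 (0.07 log units; within the scatter), which is expected to remain within the scatter. Compound 4 is estimated at 1000 nM, with an expected range of 480 nM to 2100 nM.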

Compound 4, half-maximal inhibitory concentration: 1770 nM
The estimate for compound 4 lay 1.8-fold (0.25 log units) below the measured number; the measured number falls inside the stated range.
By their numbers in this assay, from the lowest: compounds 3, 1, 2 and 4 (each within the scatter of the next, the first and the last beyond it).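

In this assay, going by these compounds alone, the exchange of 3,4-dimethylphenyl for 3-chlorophenyl on the amine nitrogen gives the only step beyond the scatter so far, a 2.1-fold higher number from compound 3 to compound 4 (0.31 log units; beyond the scatter), and that step is modest. The other two exchanges at this nitrogen stay within the scatter, a 1.1-fold higher number from compound 2 to compound 4 (0.02 log units; within the scatter) and a 1.8-fold higher number from compound 1 to compound 4 (0.24 log units; within the scatter), so compound 1 and compound 2 cannot be told apart from either compound 3 or compound 4. Changing this aryl group has therefore separated only compound 3 and compound 4 in this series, and no measurement on hand accounts for that step.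

The compounds shown carry only substituted phenyl groups on this nitrogen. From the compounds shown here alone, how an unsubstituted phenyl, a benzyl group or a pyridine ring would read there remains open, as does whether the modest step would recur on another core.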